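Chloro for Hydrogen on a Sulfonamide Series: Cytotoxicity Outlook

This account rests on a few compounds, and the source may have more. Where it says the series, first, only, none or still open, it means among the compounds named here.

Compound 1 `O=C(Nc1cnn(-c2ccccc2)c1)c1cccc(NS(=O)(=O)c2ccccc2)c1` gives 110000 nM in an ADME assay on HEK-293T cells (Homo sapiens) for cytotoxicity, read by MTT assay, with a stated time of 48 h; on this read-out higher numbers stand for lower toxicity in this test and lower numbers for higher toxicity in this test.
Compound 2 `COc1cccc(-n2cc(NC(=O)c3cccc(NS(=O)(=O)c4ccc(Cl)cc4)c3)cn2)c1` gives 133000 nM in this assay.
Compound 3 `Cc1ccc(-n2cc(NC(=O)c3ccc(NS(=O)(=O)c4ccccc4)cc3)cn2)cc1` gives 107000 nM in this assay.

On these numbers compound 3 stands alongside compound 1 and compound 2: all three values lie within the usual scatter of one another, so no order among them can be read. Compound 4 `Cc1ccc(-n2cc(NC(=O)c3ccc(NS(=O)(=O)c4ccc(Cl)cc4)cc3)cn2)cc1` differs from compound 3 by chloro in place of hydrogen on an aromatic carbon. Among the measured compounds shown here, no pair of measured compounds shows this change alone, so its effect here is unknown; the only chlorinated compound, compound 2, also carries a methoxy group and sits within the scatter of the others. The step of a 1.1-fold higher number from compound 3 to compound 4 (0.03 log units; within the scatter) is therefore expected to be none beyond the scatter. Compound 4 is estimated at 115000 nM, with a range from 60000 nM to 220000 nM.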

Compound 4, half-maximal cytotoxic concentration: 138000 nM
Beside the measured number, compound 4's estimate is 1.2-fold (0.08 log units) below it, and the stated range covers the measured number.
By their numbers in this assay, from the lowest: compounds 3, 1, 2 and 4 (each within the scatter of the next).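

In this assay, compound 3 and compound 4 are the only pair shown that isolates chloro in place of hydrogen on an aromatic carbon, para to a large group, and the change gives a 1.3-fold higher number from compound 3 to compound 4 (0.11 log units; within the scatter). At this place, then, phenyl to 4-chlorophenyl on the sulfonyl group leaves the read-out within the usual scatter. Nothing available bears on the reason for this result.

Going by these compounds, whether an amine or a carboxylic acid at this place would move the number beyond the scatter remains open. So does whether chloro would give a similar step on the core of compound 1.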